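Removing a Chloro from the Core of Compound 2

This account rests on a few compounds, and the source may have more. Where it says the series, first, only, none or still open, it means among the compounds named here.

Measured so far:
compound 1, `ClCc1ccc(Cn2cnc3c(Cl)ncnc32)cc1`, 1280 nM
compound 2, `ClCc1ccccc1Cn1cnc2c(Cl)nc(Cl)nc21`, 1620 nM

Of the compounds shown here, two have been tested so far in a functional assay on ACHN cells (Homo sapiens) for cytotoxicity, read by sulforhodamine B assay, with a stated time of 48 h; a lower number here means a stronger inhibitor of growth, a higher number a weaker inhibitor of growth. Compound 1 has the structure `ClCc1ccc(Cn2cnc3c(Cl)ncnc32)cc1` and gives 1280 nM. Compound 2, with the structure `ClCc1ccccc1Cn1cnc2c(Cl)nc(Cl)nc21`, gives 1620 nM, the higher of the two numbers, but its gap to compound 1 lies within the usual scatter of the measurement, so the two cannot be told apart.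

The next compound, compound 3 with the structure `ClCc1ccccc1Cn1cnc2c(Cl)ncnc21`, differs from compound 2 in one place: hydrogen in place of chloro on an aromatic carbon. Going by the values given here, no such step has yet been measured between two tested compounds, so the expected size rests on the closeness of compound 1 and compound 2 alone. The account expects the step of a 1.1-fold lower number from compound 2 to compound 3 (0.03 log units; within the scatter) to be small, not beyond the scatter, in either direction. On that basis compound 3 is estimated in this assay at 1500 nM, with a range from 600 nM to 4000 nM.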

Compound 3, concentration for total growth inhibition: 6160 nM
Beside the measured number, compound 3's estimate is 4.1-fold (0.61 log units) below it; the whole stated range lies below it.
By their numbers in this assay, from the lowest: compounds 1 and 2 (each within the scatter of the next); then compound 3.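

In this assay, the chloro on the aromatic carbon between two ring nitrogen atoms proves to count: hydrogen in its place gives a 3.8-fold higher number from compound 2 to compound 3 (0.58 log units; beyond the scatter), so compound 3 is the weaker inhibitor of growth. Going by these compounds alone, this is the first step measured across a single change, and it shows that this position is not indifferent, which the closeness of the two earlier compounds, differing in more than one place, could not show. Nothing measured here bears on what lies behind the step.

The compounds shown leave open whether chloro itself is needed at this carbon, or whether an amine or a methoxy group there would keep the number of compound 2. They also leave open whether the step keeps its size in other cell lines.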